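Trimming the triazole substituent of compound 2

The source may report more compounds than this note shows. Statements on the series, on what has been measured and on what is new or still open speak of the compounds shown alone.

For the measured compounds named here, compound 2 `O=C1O[C@H]([C@@H](O)Cn2cc(CNS(=O)(=O)c3ccc(F)cc3)nn2)C(OCc2ccccc2)=C1OCc1ccccc1` gives 41100 nM in a functional assay on SW-620 cells (Homo sapiens) for antiproliferative activity, read by MTT assay, with a stated time of 72 h (on this read-out higher numbers stand for weaker inhibition and lower numbers for stronger inhibition), and thus holds the lowest of the two numbers measured so far. Compound 3 `O=C1O/C(=C\Cn2cc(-c3cccc(O)c3)nn2)C(OCc2ccccc2)=C1OCc1ccccc1` gives 69800 nM in this assay; compound 2 and compound 3 lie within the scatter of each other. Compound 1 `COc1ccc(-c2cn(C/C=C3\OC(=O)C(OCc4ccccc4)=C3OCc3ccccc3)nn2)cc1` reaches only a limit, > 100000 nM, in this assay. Going by the values given here, the one step measured within a single change, an at least 1.4-fold lower number from compound 1 to compound 3 (0.15 log units; that floor lies within the scatter), concerns the aromatic substituent on the triazole and not the triazole carbon examined here.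

Compound 4 `O=C1O[C@H]([C@@H](O)Cn2ccnn2)C(OCc2ccccc2)=C1OCc1ccccc1` differs from compound 2 in one place: hydrogen in place of (((4-fluorophenyl)sulfonyl)amino)methyl on an aromatic carbon. Among the compounds with values here, no measured step bears on the loss of this group, so the only guide is that every number sits at the weak end and compound 1 reaches only a limit. A step of a 1.9-fold higher number from compound 2 to compound 4 (0.29 log units; within the scatter) toward weaker inhibition is therefore expected, with a real chance that only a limit is reported. Compound 4 is estimated at 80000 nM in this assay, between 30000 nM and 200000 nM.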

Compound 4, half-maximal inhibitory concentration: > 100000 nM
Compound 4 gave a limit, no number (the forecaster's own chance of this, stated with the estimate: 40%); middle value at least 1.2-fold (0.09 log units) from the limit.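

For the compounds shown here, replacing (((4-fluorophenyl)sulfonyl)amino)methyl with hydrogen gives the first single change whose step lies beyond the scatter in this assay: an at least 2.4-fold higher number from compound 2 to compound 4 (0.38 log units; beyond the scatter). Going by these compounds alone, the earlier step, an at least 1.4-fold lower number from compound 1 to compound 3 (0.15 log units; that floor lies within the scatter), concerned only the aromatic substituent, so this result is the first sign that the group on this aromatic carbon of the five-membered aromatic ring with 3 nitrogen matters for the read-out, though compound 2 itself remains weak. The size of the step is only a floor, since compound 4 gives a limit and not a number: the limit of > 100000 nM in this assay, at which 2 of the 4 values shown sit.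

The compounds shown do not tell which part of the lost group carries the step: the sulfonyl, the amino or the 4-fluorophenyl part. As far as these compounds go, whether an aminomethyl group or a carboxylic acid on this carbon would hold the number of compound 2 also stays open.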